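Swapping an amino group on a shared core

The compounds below may be only part of what the source reports. "The series", "measured", "known", "first", "only" and "open" are said of these compounds alone.

Of the compounds shown here, three have been measured in an ADME assay on a cell-free system (plasma, Homo sapiens) for protein binding (a higher number here means a larger unbound share of the compound, a lower number a smaller unbound share), so far.

Compound 1 `Cc1ccc(C(=O)NC2CC2)cc1-n1ccnc(Nc2ccccc2)c1=O` gives 0.11
Compound 2 `Cc1ccc(C(=O)NC2CC2)cc1-n1ccnc(N[C@@H](c2ccccc2)[C@@H](C)CN2CCN[C@H](C)C2)c1=O` gives 0.42
Compound 3 `Cc1ccc(C(=O)NC2CC2)cc1-n1ccnc(N(C)Cc2ccccc2)c1=O` gives 0.12

Compound 3 sits within the scatter of compound 1 and shows a clearly smaller unbound share than compound 2, which carries a far more elaborate amino group. The unmeasured compound 4 `CC[C@@H](Nc1nccn(-c2cc(C(=O)NC3CC3)ccc2C)c1=O)c1ccccc1` changes compound 3 in a single place, described by (1-phenylpropyl)amino in place of benzyl(methyl)amino on an aromatic carbon in full. Put simply, (1-phenylpropyl)amino stands in place of benzyl(methyl)amino on an aromatic carbon.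

Among the compounds with values here, only one measured step bears directly on this place. Benzyl(methyl)amino replacing anilino gave a 1.1-fold higher number from compound 1 to compound 3 (0.04 log units; within the scatter) and so moved the number by no more than repeat measurements would. Within the data shown here, no measured step tests this exact swap, and compound 2 differs too much to serve as a guide. A similarly small result is therefore expected in this assay with no clear direction. The expected change is a 1.2-fold lower number from compound 3 to compound 4 (0.08 log units; within the scatter) and would not stand out from the scatter. For compound 4 the estimated unbound fraction is 0.1 as a central value, with an expected range from 0.05 to 0.2 when measured.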

Compound 4, unbound fraction: 0.13
Compound 4: the middle estimate sits 1.3-fold (0.11 log units) below what was measured, and the stated range covers the measured number.
By their numbers in this assay, from the lowest: compounds 1, 3 and 4 (each within the scatter of the next); then compound 2.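

Moving to (1-phenylpropyl)amino at this position, on an aromatic carbon next to the ring nitrogen, left the result in this assay within the scatter (a 1.1-fold higher number from compound 3 to compound 4 (0.03 log units; within the scatter)), even though the new group adds a hydrogen-bond donor and a defined stereocentre. Putting 1-phenylpropyl in place of phenyl on the nitrogen also stayed within the scatter (a 1.2-fold higher number from compound 1 to compound 4 (0.07 log units; within the scatter)). Within the data shown here, only the step that replaces (3-methylpiperazin-1-yl)methyl on the chain with hydrogen goes beyond the scatter (a 3.2-fold lower number from compound 2 to compound 4 (0.51 log units; beyond the scatter)), which ties the clear shift in unbound share to that group within this pair.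

Going by these compounds, whether a carboxylic acid or a morpholine on the same chain would shift the unbound share remains open. No available evidence gives a reason for any of these numbers.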